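Stereochemical definition at the quinuclidine centre of the triazole series

The source may report more compounds than this note shows. Statements on the series, on what has been measured and on what is new or still open speak of the compounds shown alone.

Measured compounds:
compound 1 `Fc1cccc(-c2cn([C@@H]3CN4CCC3CC4)nn2)c1` — 2.25 nM
compound 2 `c1ccc(COc2cccc(-c3cn([C@@H]4CN5CCC4CC5)nn3)c2)cc1` — 6.67 nM
compound 3 `Fc1ccc(-c2cn(C3CN4CCC3CC4)nn2)cc1` — 8.5 nM

In an assay on HEK293 cells for displacement of a labelled ligand from Neuronal acetylcholine receptor; alpha3/beta4 (Homo sapiens), read by scintillation counting, with a stated time of 120 min (on this read-out higher numbers stand for weaker inhibition and lower numbers for stronger inhibition), compound 1 gives the lowest number of the three; compound 2 sits a 3.0-fold higher number from compound 1 to compound 2 (0.47 log units; beyond the scatter) away, and compound 3 shows a higher number still. Compound 4 `Fc1cccc(-c2cn(C3CN4CCC3CC4)nn2)c1` differs from compound 1 only in stereochemical drawing: the two compounds have the same atoms and bonds; at least one stereo element is drawn with a configuration in one of them and without one in the other: 1 of 3 stereo elements differ; a stereocentre at a saturated ring carbon is drawn S in compound 1 and without a configuration in compound 4. Going by the values given here, no measured step bears directly on this change; the step from compound 1 to compound 2 concerns a substituent swap, and compound 3 carries both a different fluoro position and an undefined centre, so its value cannot be separated into the two effects. A sample without a defined configuration is expected to read somewhat higher than the pure isomer of compound 1, estimated as a 2.0-fold higher number from compound 1 to compound 4 (0.30 log units; within the scatter). Compound 4 is therefore estimated at 4.5 nM (1.8 nM to 12 nM).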

Compound 4, inhibition constant: 5.24 nM
Compound 4: middle estimate off by 1.2-fold (0.07 log units), on the low side, and the stated range covers the measured number.
By their numbers in this assay, from the lowest: compound 1; then compounds 4, 2 and 3 (each within the scatter of the next).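

The defined S centre of compound 1 gives the lower number, with a 2.3-fold higher number from compound 1 to compound 4 (0.37 log units; beyond the scatter). Going by these compounds alone, this is the only step that isolates the stereocentre at the saturated ring carbon, so configuration at this position registers on the read-out apart from any substituent swap. The gap traces to a single structural difference: the fact that one of compounds 1 and 4 is drawn with a defined configuration and the other without, at the place where they differ

On these data alone, the reading of the pure R isomer of this core remains open, as does the composition of the sample of compound 4. Also open, as far as these compounds go, is how an amine or a carboxylic acid in place of the fluoro on the aromatic carbon would read.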